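Swapping a tert-butylphenyl for a dichlorophenyl group

This account rests on a few compounds, and the source may have more. Where it says the series, first, only, none or still open, it means among the compounds named here.

Three close relatives of one shared core have been tested in a functional assay on mitochondria from heart for inhibition of peroxisomal acyl-coenzyme A oxidase 1 (Rattus norvegicus); on this read-out higher numbers stand for weaker inhibition and lower numbers for stronger inhibition. Compound 1 `Cc1nc2cc(OC[C@H](O)CN3CCN(Cc4noc(-c5ccc(C(C)(C)C)cc5)n4)CC3)ccc2s1` gives 180 nM. Compound 2 `Cc1nc2cc(OC[C@H](O)CN3CCN(Cc4nc(-c5ccc(C(C)(C)C)cc5)no4)CC3)ccc2s1` gives 570 nM, and compound 3 `Cc1nc2cc(OC[C@H](O)CN3CCN(Cc4csc(-c5ccc(C(F)(F)F)cc5)n4)CC3)ccc2s1` gives 1300 nM. Compound 1 therefore has the lowest number of the three, and both of its gaps to the others lie beyond the usual scatter, so within this small set it is the strongest inhibitor.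

Compound 4 `Cc1nc2cc(OC[C@H](O)CN3CCN(Cc4noc(-c5ccc(Cl)cc5Cl)n4)CC3)ccc2s1` has not yet been measured. It differs from compound 1 in a single place: 2,4-dichlorophenyl in place of 4-(tert-butyl)phenyl on an aromatic carbon. Going by the values given here, no pair of measured compounds shows this particular swap, so there is no measured step to lean on, and the size and direction of the change are open. For compound 4 the expected step is a 2.2-fold higher number from compound 1 to compound 4 (0.35 log units; beyond the scatter), a modest rise in the number that may or may not reach beyond the scatter. Compound 4 is estimated at 400 nM, with a plausible range from 120 nM to 1400 nM.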

Compound 4, half-maximal inhibitory concentration: 130 nM
Estimate against measurement, compound 4: 3.1-fold (0.49 log units) above; low and high end bracket the measured number.
By their numbers in this assay, from the lowest: compounds 4 and 1 (each within the scatter of the next); then compound 2; then compound 3.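

In this assay, placing 2,4-dichlorophenyl instead of 4-(tert-butyl)phenyl on the aromatic carbon of the five-membered ring gives a 1.4-fold lower number from compound 1 to compound 4 (0.14 log units; within the scatter), so the two compounds cannot be told apart on this read-out. For this pair, then, the tert-butyl group is not needed to keep the number at the level of compound 1, and a phenyl ring carrying two chlorine atoms serves equally well at this position. Nothing available explains why these two different groups read alike.

On these data alone, it remains open whether a phenyl ring with a single chlorine, or a carboxylic acid or an amine on that ring, would also stay at this level. Also open, as far as these compounds go, is whether the same swap would read alike on the five-membered ring of compound 2.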